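Swapping the Aryl Group in a Two-Compound Cytotoxicity Series

The source may report more compounds than this note shows. Statements on the series, on what has been measured and on what is new or still open speak of the compounds shown alone.

Measured in a functional assay on HepG2 cells (Homo sapiens) for cytotoxicity, read by MTT assay, with a stated time of 48 h; a lower number here means a stronger inhibitor, a higher number a weaker inhibitor:
Compound 1 `Cc1ncc([N+](=O)[O-])n1CCSc1nnc(-c2ccc(F)cc2)o1` gives 600 nM
Compound 2 `Cc1ncc([N+](=O)[O-])n1CCSc1nnc(-c2ccc(N(C)C)cc2)o1` gives 11900 nM

For the measured compounds named here, compound 1 stands lowest of the two numbers; its only neighbour is compound 2, reached by a 20-fold higher number from compound 1 to compound 2 (1.30 log units; beyond the scatter). Compound 3 `Cc1ncc([N+](=O)[O-])n1CCSc1nnc(-c2ccncc2)o1` has not been measured and differs from compound 1 by pyridin-4-yl in place of 4-fluorophenyl on an aromatic carbon. Going by the values given here, the one step that bears on it, a 20-fold higher number from compound 1 to compound 2 (1.30 log units; beyond the scatter), also replaces the group on that aromatic carbon and was large, though with a different group, so it is only a loose guide. A smaller step toward a higher number is expected in this assay. Compound 3 is estimated at 1500 nM, between 400 nM and 6000 nM, an expected step of a 2.5-fold higher number from compound 1 to compound 3 (0.40 log units; beyond the scatter).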

Compound 3, half-maximal inhibitory concentration: 14800 nM
For compound 3 the middle estimate is 9.9-fold (0.99 log units) below the measured one; measured number above the stated range.
By their numbers in this assay, from the lowest: compound 1; then compounds 2 and 3 (each within the scatter of the next).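

In this assay, pyridin-4-yl in place of 4-fluorophenyl gives a 25-fold higher number from compound 1 to compound 3 (1.39 log units; beyond the scatter), so a second and quite different replacement at this aromatic carbon also moves the number far from that of compound 1. Compound 3 stands within the scatter of compound 2, so among the three compounds only compound 1, with 4-fluorophenyl, has the low number. No supporting measurement accounts for this result.

The compounds shown leave open whether the low number depends on the fluoro group itself or would persist with an unsubstituted phenyl or a 4-chlorophenyl. They also leave open how a pyridin-3-yl at this carbon would compare.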